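Replacing the aryl ketone of compound 3 with a dicyanoethenyl group

The source may hold more compounds than are shown below. What is called first, only, known or untested is meant among the compounds shown, and "the series" means these compounds.

Of the compounds shown here, three sharing one core have been measured in a functional assay (aorta) with Rattus norvegicus as the target; on this read-out higher numbers stand for higher potency (the scale is a negative logarithm) and lower numbers for lower potency. Compound 1 `CC1(C)C=C(n2ccccc2=O)c2cc(C(=O)c3ccco3)ccc2O1` gives 6.49. Compound 2 `CC1(C)C=C(n2ccccc2=O)c2cc(C(=O)c3ccccc3F)ccc2O1` gives 7.08, and compound 3 `Cc1ccccc1C(=O)c1ccc2c(c1)C(n1ccccc1=O)=CC(C)(C)O2` gives 6.83. Compound 3 thus stands second of the three; its number lies within the scatter of compound 2, as the step of a number 0.25 log units lower from compound 2 to compound 3 (within the scatter) shows, while against compound 1 the step of a number 0.34 log units higher from compound 1 to compound 3 (beyond the scatter) lies beyond it. The new compound 4 `CC1(C)C=C(n2ccccc2=O)c2cc(C=C(C#N)C#N)ccc2O1` differs from compound 3 in one place: 2,2-dicyanoethenyl in place of (2-methylphenyl)carbonyl on an aromatic carbon. Going by the values given here, no measured step exchanges a carbonyl-linked aryl group for a group of this kind, so the steps of a number 0.59 log units higher from compound 1 to compound 2 (beyond the scatter) and a number 0.34 log units higher from compound 1 to compound 3 (beyond the scatter) bear on it only loosely; they show that what sits at this position shifts this assay by modest amounts. He therefore expects a step of a number 0.33 log units lower from compound 3 to compound 4 (beyond the scatter) for compound 4, within the scatter or a little below. His estimate for compound 4 in this assay is 6.5, ranging from 5.8 to 7.2.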

Compound 4, logarithm of the reciprocal of the active concentration, log(1/C): 6.95
The estimate for compound 4 lay 0.45 log units below the measured number; the range from low to high includes it.
By their numbers in this assay, from the lowest: compound 1; then compounds 3, 4 and 2 (each within the scatter of the next).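

The result shows that, in this assay, a carbonyl-linked aryl ring is not required at this position for the level set by the two phenyl ketones. The ringless 2,2-dicyanoethenyl group of compound 4 stays within the scatter of both, with a number 0.12 log units higher from compound 3 to compound 4 (within the scatter) and a number 0.13 log units lower from compound 2 to compound 4 (within the scatter) as the two steps. Against the furan-2-yl ketone it behaves as those phenyl ketones do, with a number 0.46 log units higher from compound 1 to compound 4 (beyond the scatter) clear of the scatter, and no measurement at hand says why such different groups read alike.

The compounds shown leave open whether both nitrile groups are needed or the double bond alone, with a single nitrile, would hold this level. They also leave open how an amine or a carboxylic acid in this place would read.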